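Removing the methylsulfonyl group from compound 3

The source may report more compounds than this note shows. Statements on the series, on what has been measured and on what is new or still open speak of the compounds shown alone.

Measured so far in a physicochemical assay for lipophilicity, read by HPLC, at pH 7.5; on this read-out higher numbers stand for higher lipophilicity and lower numbers for lower lipophilicity 
Compound 1 `CC[C@@H](Nc1c(C#N)c(-c2ccc(-c3ccccc3F)cc2)nc2cnccc12)C(N)=O` gives 2.7 
Compound 2 `CCOc1ccccc1-c1ccc(-c2nc3cnccc3c(N[C@H](CC)C(=O)NS(=O)(=O)C3CC3)c2C#N)cc1` gives 2.3 
Compound 3 `CCOc1ccccc1-c1ccc(-c2nc3cnccc3c(N[C@H](CC)C(=O)NS(C)(=O)=O)c2C#N)cc1` gives 2.2 

Compound 3 stands at 2.2 and cannot be told apart from compound 2 at 2.3 within the scatter, while compound 1 at 2.7 lies beyond the scatter above both. Compound 4 `CCOc1ccccc1-c1ccc(-c2nc3cnccc3c(N[C@H](CC)C(N)=O)c2C#N)cc1` has hydrogen in place of methylsulfonyl on an amide-type nitrogen and so carries carbamoyl, as compound 1 does.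

Going by the values given here, the only measured step near this place is a number 0.10 log units lower from compound 2 to compound 3 (within the scatter) and it merely swaps the group on the sulfonyl sulfur, so it says little about losing the whole methylsulfonyl. Among the compounds with values here, no measured pair isolates this change. Within the data shown here, the best guide is compound 1 at 2.7 as the only measured compound with carbamoyl, although its far end differs. A rise beyond the scatter is therefore expected in this assay and the expected size is a number 0.70 log units higher from compound 3 to compound 4 (beyond the scatter) in this estimate. Compound 4 is estimated at 2.9 with an expected range from 2.5 to 3.3 for the coming measurement.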

Compound 4, distribution coefficient: 3
Beside the measured number, compound 4's estimate is 0.10 log units below it, and the stated range covers the measured number.
By their numbers in this assay, from the lowest: compounds 3 and 2 (each within the scatter of the next); then compounds 1 and 4 (each within the scatter of the next).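

In this assay, the hydrogen in place of methylsulfonyl on the amide-type nitrogen gives a number 0.80 log units higher from compound 3 to compound 4 (beyond the scatter) and the hydrogen in place of cyclopropylsulfonyl at the same place gives a number 0.70 log units higher from compound 2 to compound 4 (beyond the scatter). The earlier step at this position changed only the group on the sulfonyl sulfur and gave a number 0.10 log units lower from compound 2 to compound 3 (within the scatter), so the two new steps show that removing the whole sulfonyl group moves this read-out beyond the scatter, whichever of the two groups leaves. With carbamoyl on both compounds, ethoxy in place of fluoro on an aromatic carbon gives a number 0.30 log units higher from compound 1 to compound 4 (within the scatter), which stays within the scatter.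

No measurement shown gives a reason for these steps. From the compounds shown here alone, how a carboxylic acid in place of carbamoyl, or an acetyl group on the amide-type nitrogen, would read in this assay remains open.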